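Hydroxy to Methoxy in Two Anilide Cores

The compounds below may be only part of what the source reports. "The series", "measured", "known", "first", "only" and "open" are said of these compounds alone.

Measured compounds in an ADME assay on HEK293 cells (Homo sapiens) for cytotoxicity, read by reporter gene assay and resazurin assay, with a stated time of 48 h; a higher number here means that more compound is tolerated, a lower number that less compound is tolerated:
compound 1, `O=C(Nc1ccc(Sc2nc3ccccc3s2)c(Cl)c1)c1cccc(Br)c1O`, 64000 nM
compound 2, `COc1c(Br)cccc1C(=O)Nc1ccc(Sc2nc3ccccc3s2)c(Cl)c1`, > 100000 nM
compound 3, `O=C(Nc1cccc(Cl)c1)c1cccc(Br)c1O`, 32000 nM

The value given for compound 2 is a limit of this assay and not a number, as set out in the limit of > 100000 nM in this assay, at which 1 of the 3 values shown sits. The change from compound 1 to compound 2 is methyl in place of hydrogen on an oxygen on an aromatic ring, and in this assay it gives an at least 1.5-fold higher number from compound 1 to compound 2 (0.19 log units; that floor lies within the scatter).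

Compound 3 carries a different core; how the core of compound 3 differs from the core of compound 1 is not broken down here. In this assay compound 3 gives 32000 nM, and compound 1 gives 64000 nM, the two lying within the usual scatter of each other.

Compound 4, `COc1c(Br)cccc1C(=O)Nc1cccc(Cl)c1`, has not yet been measured. It differs from compound 3 by methyl in place of hydrogen on an oxygen on an aromatic ring, the same change as that between compound 1 and compound 2, made at the same kind of place on the other core. The step expected in this assay is a 2.0-fold higher number from compound 3 to compound 4 (0.30 log units; within the scatter). This rests on the earlier step of an at least 1.5-fold higher number from compound 1 to compound 2 (0.19 log units; that floor lies within the scatter). Compound 4 is therefore estimated at 64000 nM, with an expected span from 25000 nM to 150000 nM.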

Compound 4, half-maximal cytotoxic concentration: > 100000 nM
Compound 4 gave a limit, no number; the forecaster's own chance of this, stated with the estimate: 30%; middle value at least 1.5-fold (0.19 log units) away from the limit.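

In this assay, hydroxy to methoxy on the core of compound 3 gives an at least 3.1-fold higher number from compound 3 to compound 4 (0.49 log units; beyond the scatter), so on this core the change raises the number by more than the usual scatter, whereas on the core of compound 1 the floor of the step, an at least 1.5-fold higher number from compound 1 to compound 2 (0.19 log units; that floor lies within the scatter), does not by itself clear that scatter. Compound 4 gives > 100000 nM, which is a limit of the assay and not a number: the limit of > 100000 nM in this assay, at which 2 of the 4 values shown sit. From the compounds shown here alone, the two cores therefore agree in showing no fall in the number with this change, but the true size of the step on either core stays unknown, and no claim can be made that it is the same or different on the two: the same change on two cores in this assay, an at least 1.5-fold higher number (0.19 log units; that floor lies within the scatter) from compound 1 to compound 2 and an at least 3.1-fold higher number (0.49 log units; beyond the scatter) from compound 3 to compound 4; the limit leaves it open whether they differ.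

The compounds shown leave open how a longer chain on the oxygen, such as ethoxy, would read in this assay, and whether an amine in place of the hydroxy would behave like methoxy. They also leave open whether the change would carry to any core beyond these two.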